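Urea aryl variation on the shared core: compound 4

The source may report more compounds than this note shows. Statements on the series, on what has been measured and on what is new or still open speak of the compounds shown alone.

Measured so far:
- compound 1 `COc1cc(-c2nn(-c3cccc(NC(=O)Nc4cc(C(F)(F)F)cc(C(F)(F)F)c4)c3)cc2-c2ccncc2)ccc1Cl`: 3000 nM
- compound 2 `COc1cc(-c2nn(-c3cccc(NC(=O)c4cccc(C(F)(F)F)c4)c3)cc2-c2ccncc2)ccc1Cl`: > 50000 nM
- compound 3 `COc1cc(-c2nn(-c3cccc(NC(=O)Nc4ccc(Cl)c(Cl)c4)c3)cc2-c2ccncc2)ccc1Cl`: 12900 nM

In a functional assay on MDA-MB-231 cells (Homo sapiens) for inhibition, read by sulforhodamine B assay, with a stated time of 48 h (on this read-out higher numbers stand for lower toxicity in this test and lower numbers for higher toxicity in this test), compound 3 gives 12900 nM, the highest number among the two compounds with a number; compound 1 sits at 3000 nM, a lower number beyond the scatter. Compound 2 gives only a limit, > 50000 nM, with no number reported (the limit of > 50000 nM in this assay, at which 1 of the 3 values shown sits).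

Compound 4 `COc1cc(-c2nn(-c3cccc(NC(=O)Nc4cccc(C(F)(F)F)c4)c3)cc2-c2ccncc2)ccc1Cl` has not yet been measured in this assay. It differs from compound 3 in one place (3-(trifluoromethyl)phenyl in place of 3,4-dichlorophenyl on an amide-type nitrogen). Among the compounds with values here, the only measured step that touches this aryl group is an at least 3.8-fold lower number from compound 2 to compound 3 (0.58 log units; beyond the scatter), but there the carbonyl also changed from amide to urea, so it does not isolate the aryl change. Within the data shown here, compound 1 carries a urea too, with a bis(trifluoromethyl)phenyl, and its number is lower than that of compound 3, yet no single step separates the two.

With a urea kept and one trifluoromethyl in place of two chlorines, the expected outcome for compound 4 is a number close to compound 3, within the scatter, a 1.3-fold lower number from compound 3 to compound 4 (0.11 log units; within the scatter). Compound 4 is thus estimated at 10000 nM, with a range from 3000 nM to 35000 nM.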

Compound 4, concentration lethal to 50% of the cells: 25500 nM
The estimate for compound 4 lay 2.6-fold (0.41 log units) below the measured number, and the stated range covers the measured number.
By their numbers in this assay, from the lowest: compound 1; then compounds 3 and 4 (each within the scatter of the next). At a limit, above all of these: compound 2.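

On the urea nitrogen, 3-(trifluoromethyl)phenyl in place of 3,4-dichlorophenyl gives a 2.0-fold higher number from compound 3 to compound 4 (0.30 log units; within the scatter) in this assay, so these two aryl groups are not told apart at this position. Within the data shown here, the one-place comparison that compound 3 could not give comes with hydrogen in place of trifluoromethyl on an aromatic carbon, an 8.5-fold higher number from compound 1 to compound 4 (0.93 log units; beyond the scatter), which ties the lower number of compound 1 to the one trifluoromethyl that compound 4 lacks. With the aryl group held, the change from amide to urea reads an at least 1.9-fold lower number from compound 2 to compound 4 (0.29 log units; that floor lies within the scatter); compound 2 is a limit and not a number, so this step gives only a floor and no size for the change: the limit of > 50000 nM in this assay, at which 1 of the 4 values shown sits.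

Open, going by these compounds, is whether the gap between compound 1 and compound 4 belongs to trifluoromethyl itself, or would also appear with a nitrile, an amine or a carboxylic acid in the place of that group. Also open, on these data alone, is whether the same hydrogen-for-trifluoromethyl step would give a gap of similar size on the amide series or with other urea aryl groups.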